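Replacing the Lactam on the Compound 1 Core

The source may report more compounds than this note shows. Statements on the series, on what has been measured and on what is new or still open speak of the compounds shown alone.

In a functional assay (trachea) for inhibition, with Cavia porcellus as the target (a higher number here means a weaker inhibitor, a lower number a stronger inhibitor), compound 1 `CC1(C)c2ccc([N+](=O)[O-])cc2[C@@H](N2CCCC2=O)[C@@H]1O` gives 2800 nM, the higher of the two exact numbers in the series. Compound 3 `CC1(C)c2ccc(I)cc2[C@@H](N2CCCCC2=O)[C@@H]1O` gives 300 nM, a lower number and beyond the scatter, but it differs from compound 1 in more than one place. Compound 2 `CC1(C)c2ccc([N+](=O)[O-])cc2[C@@H](N2CCCC2=O)[C@H]1O` reads > 20000 nM, which is a limit of the assay.

Compound 4 `CC1(C)c2ccc([N+](=O)[O-])cc2[C@@H](n2ccccc2=O)[C@@H]1O` changes the group on the saturated ring carbon next to the ring atom that bears a hydroxy group: a group of 7 heavy atoms (5 carbon, 1 nitrogen, 1 oxygen; one six-membered aromatic ring with 1 hetero atom) in place of a group of 6 heavy atoms (4 carbon, 1 nitrogen, 1 oxygen; one five-membered non-aromatic ring with 1 hetero atom), on a saturated ring carbon.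

For the measured compounds named here, the only measured step is an at least 7.1-fold higher number from compound 1 to compound 2 (0.85 log units; beyond the scatter), and its size stays open because of the limit of > 20000 nM in this assay, at which 1 of the 3 values shown sits. That step rests on (the fact that compounds 1 and 2 differ only in the configuration as drawn), whereas compound 4 keeps the drawn configuration of compound 1, so it does not size this exchange. Going by the values given here, no measured step isolates the new group, so no shift beyond the scatter is expected in this assay, and the direction stays uncertain. The expected step is a 1.6-fold lower number from compound 1 to compound 4 (0.19 log units; within the scatter). Compound 4 is estimated at 1800 nM, with an expected range of 350 nM to 9000 nM.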

Compound 4, half-maximal inhibitory concentration: 150 nM
Beside the measured number, compound 4's estimate is 12-fold (1.08 log units) above it; measured number below the stated range.
By their numbers in this assay, from the lowest: compounds 4 and 3 (each within the scatter of the next); then compound 1. At a limit, above all of these: compound 2.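

Exchanging the 2-oxopyrrolidin-1-yl group for the six-membered aromatic ring with 1 hetero atom gives a 19-fold lower number from compound 1 to compound 4 (1.27 log units; beyond the scatter) in this assay. For the compounds shown here, the earlier compounds offered only a change of configuration as drawn, so this is the first readable sign that the group on this saturated ring carbon itself moves the number, with the drawn configuration of compound 1 kept. Nothing at hand accounts for the size of this step or identifies which feature of the entering group carries it.

Going by these compounds, it stays open whether the ring carbonyl is needed, which a plain phenyl group or an open-chain acetamide on this carbon would test. On these data alone, it also stays open whether the same exchange holds with iodine in place of the nitro group on the shared core.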